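A few compounds are considered here, and "the series" means these few. Any claim that something is new, unique, unknown or untested is made for them only; others in the source may bear on it.

Among the measured compounds shown here, compound 1 `CN1CCN(c2ccc(Nc3nc(-c4cccc(NC(=O)c5ccccc5)c4)sc3C(=O)O)cc2)CC1` is recorded as "not determined" (no result reported) in a functional assay on Raji cells (Homo sapiens) for antiproliferative activity, read by CCK-8 assay, with a stated time of 72 h; a higher number here means a weaker inhibitor, a lower number a stronger inhibitor; it belongs to a small group of close relatives of which only two carry numbers. Compound 2 `CN1CCN(c2ccc(Nc3nc(-c4cccc(NC(=O)c5cccc(F)c5)c4)sc3C(=O)O)cc2)CC1` gives 35100 nM in this assay, and compound 3 `CN1CCN(c2ccc(Nc3nc(-c4cccc(NC(=O)c5ccc(Cl)cc5)c4)sc3C(=O)O)cc2)CC1` gives 7020 nM. For the measured compounds named here, the only step between measured neighbours is a 5.0-fold lower number from compound 2 to compound 3 (0.70 log units; beyond the scatter), a change at the benzamide end of the molecule. Compound 4 `CN1CCN(c2ccc(Nc3nc(-c4cccc(NC(=O)c5ccccc5)c4)sc3C(N)=O)cc2)CC1` is drawn from compound 1 by a different change, (amino in place of hydroxy on a carbonyl carbon), so that a carboxy group becomes a carbamoyl group. Going by the values given here, no measured step in this assay touches that position, and compound 1 itself has no number, so nothing here shows how large a shift this exchange produces or in which direction. What can be drawn on is only the range in which the two measured relatives sit. On that basis compound 4 is expected to give about 15000 nM in this assay, with a plausible range from 2000 nM to 80000 nM, an estimate that rests on the general weakness of the measured relatives rather than on any step of its own.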

Compound 4, half-maximal inhibitory concentration: 6360 nM
Compound 4: middle estimate off by 2.4-fold (0.37 log units), on the high side; measured number inside the range.
By their numbers in this assay, from the lowest: compounds 4 and 3 (each within the scatter of the next); then compound 2.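

No new step can be read for compound 4, since its one-place partner, compound 1, stands as "not determined" (no result reported) in this assay. No evidence shown bears on this result. Left open is how far, and in which direction, carboxy to carbamoyl moves the number.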